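Removing the amino group from compound 1

This account rests on a few compounds, and the source may have more. Where it says the series, first, only, none or still open, it means among the compounds named here.

Compound 1 (`COc1ccc(N(C)c2nc(N)nc3c2CCC3)cc1`): 16.7 nM
Compound 2 (`COc1ccc(N(C)c2nc(N)nc3c2CC(C)C3)cc1`): 29.9 nM
Compound 3 (`COc1ccccc1N(C)c1nc(N)nc2c1CCC2`): > 1000 nM, a limit
Compound 4 (`COc1ccc(N(C)c2ncnc3c2CCC3)cc1`): not yet measured

In a functional assay on MDA-MB-435 cells (Homo sapiens) for inhibition, read by sulforhodamine B assay, with a stated time of 48 h (a higher number here means a weaker inhibitor, a lower number a stronger inhibitor), compound 1 gives 16.7 nM and has a single numeric neighbour, which lies within the scatter of it. The change to compound 4 is hydrogen in place of amino on an aromatic carbon, between two ring nitrogen atoms. Within the data shown here, the one measured step, a 1.8-fold higher number from compound 1 to compound 2 (0.25 log units; within the scatter), is methyl in place of hydrogen on a saturated ring carbon and does not touch this place. The series therefore gives no size for this change. No step beyond the scatter is expected in this assay, and no direction is favoured. The expected step is a 1.2-fold higher number from compound 1 to compound 4 (0.08 log units; within the scatter). Compound 4 is estimated at 20 nM, with an expected range of 5 nM to 100 nM.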

Compound 4, half-maximal inhibitory concentration: 43 nM
Estimate against measurement, compound 4: 2.2-fold (0.33 log units) below, within the range that was stated.
By their numbers in this assay, from the lowest: compounds 1, 2 and 4 (each within the scatter of the next, the first and the last beyond it). At a limit, above all of these: compound 3.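

Hydrogen in place of amino on an aromatic carbon, between two ring nitrogen atoms, gives the first numeric step in the series that lies beyond the scatter: in this assay it is a 2.6-fold higher number from compound 1 to compound 4 (0.41 log units; beyond the scatter). The amino group is not essential for activity in this assay, as compound 4 still gives 43 nM, but its loss has a modest cost. No measurement shown accounts for this step.

Going by these compounds, whether a methyl or a methylamino group at this position would match compound 1 remains open. So does whether the step would be the same size on the core of compound 2.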